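Compound 4: 1H-pyrazol-4-yl in place of 5-methyl-1,2-oxazol-3-yl

This account rests on a few compounds, and the source may have more. Where it says the series, first, only, none or still open, it means among the compounds named here.

In an ADME assay on a cell-free system (plasma, Mus musculus) for protein binding, compound 1 `Cc1cc(Nc2ccc(S(F)(F)(F)(F)F)cc2)n2nc(C(F)(F)F)nc2n1` gives 97%, compound 2 `Cc1c(Cc2ccc(C(F)(F)F)nc2)c[nH]c1C(=O)NC(C)c1cnn(C)c1` gives 93.6% and compound 3 `Cc1cc(C(C)NC(=O)c2[nH]cc(Cc3ccc(C(F)(F)F)nc3)c2C)no1` gives 92.2%. Compound 3 therefore stands level with compound 2, within the scatter, and clearly apart from compound 1, which has the smallest unbound fraction of the three.

Compound 4 `Cc1c(Cc2ccc(C(F)(F)F)nc2)c[nH]c1C(=O)NC(C)c1cn[nH]c1` has not yet been measured. It carries 1H-pyrazol-4-yl in place of 5-methyl-1,2-oxazol-3-yl on a saturated chain carbon bound to an amide-type nitrogen and a saturated chain carbon.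

Among the measured compounds shown here, only one measured step bears on this place. It put 5-methyl-1,2-oxazol-3-yl in place of 1-methyl-1H-pyrazol-4-yl and gave a 1.2-fold higher unbound fraction from compound 2 to compound 3 (0.09 log units; within the scatter). One small step is thin evidence, but it offers no reason to expect a large change here. The expected change is a 1.2-fold higher unbound fraction from compound 3 to compound 4 (0.09 log units; within the scatter), which would not be a step beyond the scatter. In this assay, the estimated value for compound 4 is 90.5%, with an expected range of 84% to 94.5%.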

Compound 4, plasma protein binding in the Mus musculus assay: 92.1%
Estimate against measurement, compound 4: 1.2-fold (0.08 log units) (unbound fraction) above; the range from low to high includes it.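

In the Mus musculus assay, the two new steps at this position both stay within the scatter: a 1.0-fold higher unbound fraction from compound 3 to compound 4 (0.01 log units; within the scatter), and, with hydrogen in place of methyl on an aromatic nitrogen, a 1.2-fold higher unbound fraction from compound 2 to compound 4 (0.09 log units; within the scatter). Compounds 2, 3 and 4 thus lie level on plasma protein binding, although they carry three different five-membered aromatic rings at this place. In a physicochemical assay for solubility, in simulated intestinal fluid, with a stated time of 5 h, at pH 6.5 (on this read-out higher numbers stand for higher solubility and lower numbers for lower solubility), compound 3 gives 9.9 ug/mL and compound 4 gives 34 ug/mL. The exchange of 5-methyl-1,2-oxazol-3-yl for 1H-pyrazol-4-yl does separate compound 3 and compound 4 in the physicochemical assay: the measured solubility of compound 3, 9.9 ug/mL, and of compound 4, 34 ug/mL, a 3.4-fold higher number (0.54 log units; beyond the scatter)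

With this single pair, the compounds shown cannot tell whether the solubility gain belongs to the ring exchange as a whole or to the hydrogen on the aromatic nitrogen. Also open, going by these compounds, is how an amine or a carboxylic acid on this saturated chain carbon would behave in the Mus musculus assay and in the physicochemical assay.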